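The source may report more compounds than this note shows. Statements on the series, on what has been measured and on what is new or still open speak of the compounds shown alone.

Of the compounds shown here, three of one shared core have been measured in a functional assay for inhibition of sodium/hydrogen exchanger (Oryctolagus cuniculus); a higher number here means a weaker inhibitor, a lower number a stronger inhibitor. Compound 1 `CCc1cc(Cl)c(S(C)(=O)=O)cc1C(=O)N=C(N)N` gives 63 nM. Compound 2 `Cc1ccc(-c2ccc(C(=O)N=C(N)N)cc2S(C)(=O)=O)cc1` gives 100 nM. Compound 3 `CS(=O)(=O)c1cc(C(=O)N=C(N)N)ccc1C(F)(F)F` gives 140 nM, the highest of the three numbers; its gap to compound 2 lies within the scatter, while its gap to compound 1 lies beyond it.

The step under consideration leads from compound 3 to compound 4 `CS(=O)(=O)c1cc(C(=O)N=C(N)N)ccc1Cl`, which is not yet measured. The change is chloro in place of trifluoromethyl on an aromatic carbon. Going by the values given here, only one measured step touches the same place on the ring: a 1.4-fold higher number from compound 2 to compound 3 (0.15 log units; within the scatter). That step swapped a large group for trifluoromethyl and moved the number by an amount that does not count as a real difference. A chloro group is also carried by compound 1, which differs from compound 4 in more than one place; in this respect the value of compound 1, 63 nM, only hints that a chloro there is compatible with a low number.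

With one uninformative step to lean on, the expectation for a 1.3-fold lower number from compound 3 to compound 4 (0.10 log units; within the scatter) is a step within the scatter, if anything slightly downward. Compound 4 is therefore estimated at 110 nM, within a range from 50 nM to 250 nM.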

Compound 4, half-maximal inhibitory concentration: 380 nM
Compound 4: middle estimate off by 3.5-fold (0.54 log units), on the low side; the measured number lies above the stated range.
By their numbers in this assay, from the lowest: compounds 1, 2 and 3 (each within the scatter of the next, the first and the last beyond it); then compound 4.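

In this assay, the place ortho to a methylsulfonyl group proves sensitive to which group it carries: putting chloro there in place of trifluoromethyl gives a 2.7-fold higher number from compound 3 to compound 4 (0.43 log units; beyond the scatter), and putting chloro there in place of 4-methylphenyl gives a 3.8-fold higher number from compound 2 to compound 4 (0.58 log units; beyond the scatter), even though the earlier step between those two larger groups stayed within the scatter. Chloro at this place does not by itself give a low number, since the step of a 6.0-fold higher number from compound 1 to compound 4 (0.78 log units; beyond the scatter), hydrogen in place of ethyl on another aromatic carbon, shows that compound 1 and compound 4 carry the same chloro yet stand clearly apart. No measurement available here explains why either change moves the number.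

Going by these compounds, with only chloro, trifluoromethyl and 4-methylphenyl at this place, it remains open how other groups, such as a methoxy group, an amine or a nitrile, would fare there. On these data alone, it also remains open whether adding ethyl to the shared core would lower the number to the same degree when trifluoromethyl, rather than chloro, sits ortho to the methylsulfonyl group.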